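The source may hold more compounds than are shown below. What is called first, only, known or untested is meant among the compounds shown, and "the series" means these compounds.

Notes on the series. Among the compounds with values here, compound 1 `CCC[C@H](O)Nc1nc(Nc2ccc(-c3ncccn3)cc2)c2ncn(C(C)C)c2n1` is the only member with a number: in an assay on isolated protein (Asteroidea) for inhibition of G2/mitotic-specific cyclin-B (Asterina pectinifera), read by scintillation counting and 33P incorporation, with a stated time of 30 min (on this read-out lower numbers stand for stronger inhibition and higher numbers for weaker inhibition), compound 1 gives 500 nM. Compound 2 `CC(C)C[C@@H](O)Nc1nc(Nc2ccc(-c3ncccn3)cc2)c2ncn(C(C)C)c2n1` has in this assay only the entry "not determined" (no result reported), so nothing can be read from it against compound 1. Compound 1 therefore stands alone on the numbers shown, with no measured step to another compound. Compound 3 `CCC[C@H](O)Nc1nc(Nc2ccc(-c3cncnc3)cc2)c2ncn(C(C)C)c2n1` is the next point. It differs from compound 1 in one place: pyrimidin-5-yl in place of pyrimidin-2-yl on an aromatic carbon. Within the data shown here, no step between measured compounds is available to size this change, and the ring that leaves and the ring that enters are counted as alike in atoms and acceptors. A step of modest size is expected, somewhat toward weaker inhibition, though a step within the scatter cannot be ruled out; the expected step is a 1.6-fold higher number from compound 1 to compound 3 (0.20 log units; within the scatter). For compound 3 the estimated value in this assay is 800 nM, with a range from 200 nM to 3000 nM.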

Compound 3, half-maximal inhibitory concentration: 70 nM
The estimate for compound 3 lay 11-fold (1.06 log units) above the measured number; measured number outside the range, below it.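

In this assay this position is sensitive to how the ring is attached: pyrimidin-5-yl in place of pyrimidin-2-yl gives a 7.1-fold lower number from compound 1 to compound 3 (0.85 log units; beyond the scatter) at the aromatic carbon para to a large group. The two rings count alike in heavy atoms, hetero atoms and hydrogen-bond acceptors, so these counts do not separate compound 1 from compound 3, and the step comes with the same atoms joined differently. The data shown offer no independent measurement that explains this step.

On these data alone, whether the ring nitrogens are needed at all stays open, as a phenyl or pyridin-3-yl group at this place would test that. Also open, as far as these compounds go, is whether an amine or a carboxylic acid on the pyrimidin-5-yl ring would keep the lower number of compound 3 in this assay.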